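A few compounds are considered here, and "the series" means these few. Any claim that something is new, unique, unknown or untested is made for them only; others in the source may bear on it.

Two compounds here share one core and differ only in the aromatic group attached to the thiourea-type nitrogen. Compound 1, `COc1ccccc1NC(=S)N/N=C/c1ccc2ccccc2n1`, carries a 2-methoxyphenyl there, and in a functional assay on HL-60 cells (Homo sapiens) for antiproliferative activity, read by sulforhodamine B assay, with a stated time of 72 h (a higher number here means a weaker inhibitor, a lower number a stronger inhibitor), compound 1 gives 91700 nM. Compound 2, `CC(C)c1cccc(C(C)C)c1NC(=S)N/N=C/c1ccc2ccccc2n1`, carries a differently substituted phenyl at the same place, and in this assay compound 2 gives 19500 nM. Of these two numbers, compound 1 has the higher one, so compound 1 is the weaker inhibitor of the pair, and the gap between them lies beyond the usual scatter of repeated measurements.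

Compound 3, `Fc1cccc(NC(=S)N/N=C/c2ccc3ccccc3n2)c1`, has not been measured. It differs from compound 1 in one place: 3-fluorophenyl in place of 2-methoxyphenyl on an amide-type nitrogen. Among the compounds with values here, no measured pair in this set shows this particular swap, so the direction rests on little. Within the data shown here, the only change seen, from compound 1 to compound 2, lowered the number, which hints that the 2-methoxyphenyl of compound 1 is not the best choice at this position, but nothing shows whether 3-fluorophenyl does better. The step of a 1.8-fold lower number from compound 1 to compound 3 (0.26 log units; within the scatter) is expected to be a modest lowering, close to the edge of the scatter. Compound 3 is therefore estimated to give 50000 nM in this assay, with a plausible range from 10000 nM to 200000 nM.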

Compound 3, half-maximal inhibitory concentration: 43800 nM
For compound 3 the middle estimate is 1.1-fold (0.06 log units) above the measured one; the measured number falls inside the stated range.
By their numbers in this assay, from the lowest: compound 2; then compound 3; then compound 1.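

In this assay, the change to 3-fluorophenyl gives a 2.1-fold lower number from compound 1 to compound 3 (0.32 log units; beyond the scatter), so this position responds to a swap between two single substituted phenyl groups, not only to the change seen with compound 2. The step also shows that the hydrogen-bond acceptor counted in the 2-methoxyphenyl of compound 1 is not required to reach this level of activity, since the 3-fluorophenyl of compound 3 has none and still gives a lower number. Nothing measured here explains why the number fell, so the step remains an observation without a known cause.

Compound 3 at 43800 nM still has a higher number than compound 2 at 19500 nM, and this single swap cannot show whether the gain over compound 1 comes from the loss of the methoxy group, the presence of fluorine, or where the substituent sits on the phenyl ring. The compounds shown also leave open how a plain phenyl with no substituent would compare, and whether a phenyl bearing an amine or a carboxylic acid would be tolerated at this position.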